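The compounds below may be only part of what the source reports. "The series", "measured", "known", "first", "only" and "open" are said of these compounds alone.

Measured compounds in a functional assay on MCF7 cells (Homo sapiens) for cytotoxicity, read by XTT assay, with a stated time of 24 h; on this read-out higher numbers stand for weaker inhibition and lower numbers for stronger inhibition:
Compound 1 `Cc1cc(Cl)c2c(c1O)C(=O)C=CC2=O`: compound 1 gives 10000 nM.
Compound 2 `Cc1cc(O)c2c(c1Cl)C(=O)C=CC2=O`: compound 2 gives 15700 nM.
Compound 3 `CCOc1c(C)cc(Cl)c2c1C(=O)C=CC2=O`: compound 3 gives 32200 nM.

The three measured compounds share a common framework. Compound 1 and compound 2 carry the same atoms joined differently, and the difference between the two cores is not broken down here. In this assay compound 1 and compound 2 lie within the usual scatter of each other, so no order can be read between them. Compound 3 is derived from compound 1 by one change, (ethyl in place of hydrogen on an oxygen on an aromatic ring), and this change brought a 3.2-fold higher number from compound 1 to compound 3 (0.51 log units; beyond the scatter).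

Going by the values given here, the unmeasured compound 4 `CCOc1cc(C)c(Cl)c2c1C(=O)C=CC2=O` is derived from compound 2 by the same change, (ethyl in place of hydrogen on an oxygen on an aromatic ring), at a place whose description matches the one in compound 1 word for word. Among the compounds with values here, the single earlier example of this change is therefore the only guide available, and it points to a weaker result after the ethyl enters. Because compound 1 moved by a 3.2-fold higher number from compound 1 to compound 3 (0.51 log units; beyond the scatter), compound 4 is expected to move from compound 2 by about a 2.9-fold higher number from compound 2 to compound 4 (0.46 log units; beyond the scatter) in this assay. On that basis compound 4 is estimated at 45000 nM in this assay, with a plausible range from 18000 nM to 110000 nM, resting on one comparison only.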

Compound 4, half-maximal inhibitory concentration: 40000 nM
Compound 4: the middle estimate sits 1.1-fold (0.05 log units) above what was measured, within the range that was stated.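

In this assay the exchange of hydroxy for ethoxy went with a 2.5-fold higher number from compound 2 to compound 4 (0.41 log units; beyond the scatter) on the second core, so the number rose on this core as it had on the core of compound 1. Set side by side, the two steps cannot be told apart in size: the same change on two cores in this assay, a 3.2-fold higher number (0.51 log units; beyond the scatter) from compound 1 to compound 3 and a 2.5-fold higher number (0.41 log units; beyond the scatter) from compound 2 to compound 4, 1.3-fold (0.10 log units) apart, within the scatter of two such steps. Going by these compounds alone, this shows that, across these two closely related cores, which carry the same atoms joined differently, the step kept its direction and stayed within the scatter in size, but it rests on only two pairs and does not show that the step would hold on a core of any other kind, nor does it say what lies behind the rise.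

The compounds shown leave open whether a longer chain such as propyl or butyl on that oxygen, or a different group there such as an amine or a carboxylic acid, would continue the same trend or break from it. They also leave open how the number would respond if the chlorine were exchanged for another group, such as fluorine or bromine, on either core.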